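A few compounds are considered here, and "the series" means these few. Any claim that something is new, unique, unknown or untested is made for them only; others in the source may bear on it.

Among the measured compounds shown here, compound 1 `N#CCCCn1c(Cn2c(=O)n(-c3ccncc3F)c3ccncc32)cc2cc(Cl)ccc21` is one of three compounds measured in an ADME assay on HeLa cells (Homo sapiens) for cytotoxicity, read by ATP content, with a stated time of 3 days; a higher number here means that more compound is tolerated, a lower number that less compound is tolerated. For compound 1 the value in this assay is recorded only as a limit of the assay, > 50000 nM. Compound 2 `CC(C)CCn1c(Cn2c(=O)n(C3CC3)c3ccncc32)nc2cccnc21` also reaches only a limit, giving > 100000 nM in this assay. Compound 3 `CS(=O)(=O)CCCn1c(Cn2c(=O)n(C3CC3)c3ccncc32)cc2ccccc21` likewise stops at a limit, > 100000 nM in this assay. Where compound 1 stands among these numbers is therefore told only by limits: its own limit, (the limit of > 50000 nM in this assay, at which 1 of the 3 values shown sits), sits below the other limit, (the limit of > 100000 nM in this assay, at which 2 of the 3 values shown sit), and no number separates the three compounds.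

Compound 4 `N#CCCCn1c(Cn2c(=O)n(-c3ccncc3)c3ccncc32)cc2cc(Cl)ccc21` is the compound not yet measured. It differs from compound 1 in one place: hydrogen in place of fluoro on an aromatic carbon, that is, 3-fluoropyridin-4-yl becomes pyridin-4-yl. For the measured compounds named here, since the values of compounds 1, 2 and 3 in this assay are all limits, no measured step shows what such a change does here. The expected step from compound 1 to compound 4 in this assay is none beyond the scatter, a step that the limit leaves unreadable from compound 1 to compound 4. For compound 4 the estimate in this assay is 60000 nM, with a range from 30000 nM to 120000 nM, and the measurement is expected most likely to come back as a limit again.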

Compound 4, half-maximal cytotoxic concentration: > 50000 nM
Compound 4 gave a limit, no number (the forecaster's own chance of this, stated with the estimate: 75%); the middle value does not contradict the limit.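

In this assay compound 4 gives > 50000 nM, a limit of the assay. Compound 1 gives > 50000 nM, also a limit, so no step can be read between compound 1 and compound 4. The compounds shown leave open what hydrogen in place of fluoro on an aromatic carbon does to the half-maximal cytotoxic concentration.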